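Pyridin-4-yl for 4-fluorophenyl on the amide nitrogen

The source may hold more compounds than are shown below. What is called first, only, known or untested is meant among the compounds shown, and "the series" means these compounds.

Measured compounds:
compound 1, `CC(C)n1ncc2c(C(=O)Nc3ccc(F)cc3)cc(-c3cccs3)nc21`: > 200000 nM
compound 2, `CC(C)n1ncc2c(NC(=O)c3ccc(F)cc3)cc(-c3cccs3)nc21`: 50000 nM

Of the compounds shown here, two have been measured in an ADME assay on LLC-MK2 cells (Macaca mulatta) for cytotoxicity, read by spectrophotometry and crystal violet staining, with a stated time of 4 days; on this read-out higher numbers stand for lower toxicity in this test and lower numbers for higher toxicity in this test. Compound 1 gives only a limit in this assay, > 200000 nM, and not a number. Compound 2, which carries the amide the other way round, gives 50000 nM in this assay. Going by the values given here, no step between these two compounds is computed here, so their values are simply set side by side. Compound 1 therefore stands at the limit of > 200000 nM in this assay, at which 1 of the 2 values shown sits, with no numerical position of its own.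

Compound 3, `CC(C)n1ncc2c(C(=O)Nc3ccncc3)cc(-c3cccs3)nc21`, is not yet measured. It differs from compound 1 in one place: pyridin-4-yl in place of 4-fluorophenyl on an amide-type nitrogen. Among the compounds with values here, since no measured step is available for this kind of change, the expectation rests on compound 1 alone. The step from compound 1 to compound 3 in this assay is expected to be a number no higher from compound 1 to compound 3 (the limit leaves the size open), that is, no change beyond the usual scatter, and most likely another limit. The value of compound 3 in this assay is estimated at 200000 nM, within a range of 60000 nM to 500000 nM.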

Compound 3, half-maximal cytotoxic concentration: 6300 nM
For compound 3 the middle estimate is 32-fold (1.50 log units) above the measured one, outside the stated range (below it).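

Swapping 4-fluorophenyl for pyridin-4-yl on the amide-type nitrogen gives in this assay an at least 31-fold lower number from compound 1 to compound 3 (1.50 log units; beyond the scatter), which shows that the group at this position can move the read-out well beyond the scatter, towards higher toxicity in this test. The earlier compounds shown here could not show this, as they differ only in the direction of the amide and no step between them is available. The size of the new step is only a minimum because one end of it is a limit and not a number: the limit of > 200000 nM in this assay, at which 1 of the 3 values shown sits.

What the change does not settle is whether the ring nitrogen of pyridin-4-yl or the loss of the fluorine accounts for the step, as the two change together here, and plain phenyl or pyridin-3-yl on the same amide-type nitrogen would be needed to pull them apart. Also open, going by these compounds, is whether pyridin-4-yl would act in the same way on the reversed amide of compound 2, whose value of 50000 nM lies on a different linkage.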